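This account rests on a few compounds, and the source may have more. Where it says the series, first, only, none or still open, it means among the compounds named here.

Measured so far:

Compound 1, `COc1ccc(-n2cc(NC(=O)c3cccc(NS(=O)(=O)c4ccccc4)c3)cn2)cc1`: 35700 nM
Compound 2, `COc1ccc(-n2cc(NC(=O)c3cccc(NS(=O)(=O)c4ccc(Cl)cc4)c3)cn2)cc1`: 15200 nM
Compound 3, `Cc1ccc(-n2cc(NC(=O)c3ccc(NS(=O)(=O)c4ccccc4)cc3)cn2)cc1`: 18100 nM

All three were tested in a functional assay on HepG2 cells (Homo sapiens) for inhibition, read by MTT assay, with a stated time of 48 h; on this read-out higher numbers stand for weaker inhibition and lower numbers for stronger inhibition. Compound 1 and compound 2 share a core and differ in one place: chloro in place of hydrogen on an aromatic carbon. That single change gave a 2.3-fold lower number from compound 1 to compound 2 (0.37 log units; beyond the scatter). Compound 3 carries a different core; how it differs from compound 1 is not broken down here. Its value sits between the other two, and its gaps to compound 2 and to compound 1 are both within the usual scatter, so no order among them can be read from those pairs.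

Compound 4, `Cc1ccc(-n2cc(NC(=O)c3ccc(NS(=O)(=O)c4ccc(Cl)cc4)cc3)cn2)cc1`, has not been measured. It stands to compound 3 exactly as compound 2 stands to compound 1: chloro in place of hydrogen on an aromatic carbon. The place is the same in both pairs, so this is the same change made on a second core. If the change behaves as it did from compound 1 to compound 2, compound 4 is expected to show a 2.3-fold lower number from compound 3 to compound 4 (0.35 log units; beyond the scatter) in this assay, resting on the step of a 2.3-fold lower number from compound 1 to compound 2 (0.37 log units; beyond the scatter) and on the value of compound 3, 18100 nM. On that basis compound 4 is estimated at 8000 nM, likely between 3500 nM and 18000 nM.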

Compound 4, half-maximal inhibitory concentration: 9720 nM
For compound 4 the middle estimate is 1.2-fold (0.08 log units) below the measured one, within the range that was stated.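

On the second core, chloro in place of hydrogen gives a 1.9-fold lower number from compound 3 to compound 4 (0.27 log units; within the scatter) in this assay, a step that on its own cannot be told apart from the spread of repeated measurements. Set beside the first core, the step points the same way, and the two steps do not differ by more than repeated measurements would allow, so the result fits the change carrying over from one core to the other: the same change on two cores in this assay, a 2.3-fold lower number (0.37 log units; beyond the scatter) from compound 1 to compound 2 and a 1.9-fold lower number (0.27 log units; within the scatter) from compound 3 to compound 4, 1.3-fold (0.10 log units) apart, within the scatter of two such steps. Among the compounds shown here, this is only one pair on each of two cores in a single assay, so it does not show that the change would carry over to other cores, and it gives no reason why the numbers behave this way.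

The compounds shown leave open how other groups would behave at the same place, such as bromo, trifluoromethyl, an amine or a carboxylic acid. The two cores also differ in more than one place, so what each of those differences contributes on its own remains unresolved.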